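Capping the free phenol with a phenylsulfonylcarbamoyl group

This account rests on a few compounds, and the source may have more. Where it says the series, first, only, none or still open, it means among the compounds named here.

Compound 1, `CC(C)=CCC/C(C)=C/CC/C(C)=C/CC[C@]1(C)CCc2c(C)c(OC(=O)Nc3ccccc3)c(C)c(C)c2O1`: > 10000 nM
Compound 2, `CC(C)=CCC/C(C)=C/CC/C(C)=C/CC[C@]1(C)CCc2c(C)c(O)c(C)c(C)c2O1`: > 10000 nM

In a functional assay on MDA-MB-231 cells (Homo sapiens) for antiproliferative activity, read by MTT assay, with a stated time of 96 h (a lower number here means a stronger inhibitor, a higher number a weaker inhibitor), compound 1 gives > 10000 nM, a limit of the assay rather than a number. Compound 2 gives > 10000 nM, again only a limit. Compound 2 thus sits at the limit of > 10000 nM in this assay, at which 2 of the 2 values shown sit, so the step that the two limits leave unreadable from compound 1 to compound 2 cannot be sized. Compound 3, `CC(C)=CCC/C(C)=C/CC/C(C)=C/CC[C@]1(C)CCc2c(C)c(OC(=O)NS(=O)(=O)c3ccccc3)c(C)c(C)c2O1`, carries (phenylsulfonyl)carbamoyl in place of hydrogen on an oxygen on an aromatic ring. For the measured compounds named here, the only measured step bearing on this change is unreadable, so no step beyond the scatter can be expected in this assay. The expected step that the limit leaves unreadable from compound 2 to compound 3 is therefore about none. Compound 3 is expected to give 15000 nM, between 5000 nM and 50000 nM, most likely reported only as a limit.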

Compound 3, half-maximal inhibitory concentration: > 10000 nM
Compound 3: only a limit was reported (the forecaster's own chance of this, stated with the estimate: 80%); the middle value lies beyond the limit too.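

In this assay compound 3 gives > 10000 nM, a limit and not a number, so neither step to compound 3, from compound 1 or from compound 2, can be read: the limit of > 10000 nM in this assay, at which 3 of the 3 values shown sit.

The compounds shown leave open whether any group on this oxygen changes the activity of the shared core in this assay.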